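A few compounds are considered here, and "the series" means these few. Any claim that something is new, unique, unknown or untested is made for them only; others in the source may bear on it.

Measured so far in a functional assay on DLD-1 cells (Homo sapiens) for antiproliferative activity, read by CellTiter-Glo, with a stated time of 72 h; a lower number here means a stronger inhibitor, a higher number a weaker inhibitor:
Compound 1 `CC1CCN(C2CCN(S(=O)(=O)c3cccc(C(F)(F)F)c3)CC2)CC1` gives only a limit, > 5000 nM.
Compound 2 `COc1ccc(-c2cccc(S(=O)(=O)N3CCC(N4CCC(C)CC4)CC3)c2)cc1` gives 23 nM.
Compound 3 `CC1CCN(C2CCN(S(=O)(=O)c3cccc(-c4ccccc4)c3)CC2)CC1` gives 2 nM.

Compound 3 holds the lowest of the two numbers shown; its nearest neighbour is compound 2, with a 12-fold lower number from compound 2 to compound 3 (1.06 log units; beyond the scatter). Compound 1 sits at the limit (the limit of > 5000 nM in this assay, at which 1 of the 3 values shown sits). Compound 4 `Cc1cc(C)cc(-c2cccc(S(=O)(=O)N3CCC(N4CCC(C)CC4)CC3)c2)c1` carries 3,5-dimethylphenyl in place of phenyl on an aromatic carbon. Going by the values given here, no measured step alters the distal aromatic ring in this way; the nearest comparisons are a 12-fold lower number from compound 2 to compound 3 (1.06 log units; beyond the scatter), where a substituent on that ring went with a higher number, and an at least 2500-fold lower number from compound 1 to compound 3 (3.39 log units; beyond the scatter), where the ring itself was introduced. A small to moderate rise in this assay is therefore expected, as a 2.5-fold higher number from compound 3 to compound 4 (0.40 log units; beyond the scatter). Compound 4 is expected at 5 nM, with a range from 1.2 nM to 25 nM.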

Compound 4, half-maximal inhibitory concentration: 41 nM
Compound 4: middle estimate off by 8.2-fold (0.91 log units), on the low side, and the stated range ends below it.
By their numbers in this assay, from the lowest: compound 3; then compounds 2 and 4 (each within the scatter of the next). At a limit, above all of these: compound 1.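

On an aromatic carbon meta to a large group, the unsubstituted phenyl does not tolerate every substitution: with 3,5-dimethylphenyl there is a 21-fold higher number from compound 3 to compound 4 (1.31 log units; beyond the scatter), so a second substitution pattern on this ring, after 4-methoxyphenyl, also goes with a higher number. The two substituted rings cannot be told apart, with a 1.8-fold higher number from compound 2 to compound 4 (0.25 log units; within the scatter). The dimethylated ring still retains a large advantage over trifluoromethyl, with an at least 120-fold lower number from compound 1 to compound 4 (2.08 log units; beyond the scatter), though compound 1 gives only a limit: the limit of > 5000 nM in this assay, at which 1 of the 4 values shown sits.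

Open, as far as these compounds go, is whether a single methyl, a fluorine or an amine on the phenyl ring stays close to compound 3. Also open, from the compounds shown here alone, is how a pyridine in place of the phenyl would read.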